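The source may hold more compounds than are shown below. What is called first, only, known or untested is meant among the compounds shown, and "the series" means these compounds.

Measured in an ADME assay on NIH3T3 cells (Mus musculus) for cytotoxicity, read by MTT assay, with a stated time of 24 h; on this read-out higher numbers stand for weaker inhibition and lower numbers for stronger inhibition:
compound 1 `COc1ccccc1N1CCN(CC(=O)N2CCN(c3nnc(-c4ccccc4)c(-c4ccccc4)n3)CC2)CC1`: 444000 nM
compound 2 `COc1ccc(N2CCN(CC(=O)N3CCN(c4nnc(-c5ccc(C)cc5)c(-c5ccc(C)cc5)n4)CC3)CC2)cc1`: 116000 nM
compound 3 `COc1ccc(-c2nnc(N3CCN(C(=O)CN4CCN(c5ccccc5Cl)CC4)CC3)nc2-c2ccc(OC)cc2)cc1`: > 814000 nM

Compound 1 and compound 2 each give a number in this assay. For compound 3 the read-out is a limit of the assay, > 814000 nM, and not a number. Going by the values given here, that is the one value sitting at the limit, (the limit of > 814000 nM in this assay, at which 1 of the 3 values shown sits). Compound 3 therefore stands at the top edge of what this assay reports, with no number of its own.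

Compound 4 `COc1ccc(-c2nnc(N3CCN(C(=O)CN4CCN(c5ccc(Cl)cc5)CC4)CC3)nc2-c2ccc(OC)cc2)cc1` has not yet been measured. It differs from compound 3 only in 4-chlorophenyl in place of 2-chlorophenyl on an amine nitrogen in a ring. No measured pair of compounds differs in a single place, so no step size for this kind of change can be read from the numbers shown. Since compound 3 gives only a limit, the expected step is an at least 1.0-fold lower number from compound 3 to compound 4 (0.00 log units; that floor lies within the scatter), nothing beyond the usual scatter in either direction. Compound 4 is expected near 800000 nM, within 300000 nM to 2000000 nM, and will most likely again be reported only as a limit.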

Compound 4, half-maximal inhibitory concentration: > 814000 nM
Compound 4: no number, only a limit; the forecaster's own chance of this, stated with the estimate: 65%; at least 1.0-fold (0.00 log units) between middle value and limit.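

In this assay, going by these compounds alone, compound 4 gives > 814000 nM as a limit and not a number, and compound 3 also gives only a limit, so no step between compound 3 and compound 4 can be read. The compounds shown leave open whether 4-chlorophenyl in place of 2-chlorophenyl changes the value at all. Both compounds sit at the same edge of the read-out: the limit of > 814000 nM in this assay, at which 2 of the 4 values shown sit.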